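The source may hold more compounds than are shown below. What is called first, only, known or untested is meant among the compounds shown, and "the series" means these compounds.

Compound 1 `O=S(=O)(NCCCNCc1ccccc1Cl)c1cc(C(F)(F)F)cc(C(F)(F)F)c1` in a functional assay on MIA PaCa-2 cells (Homo sapiens) for inhibition, read by MTT assay, with a stated time of 72 h (a lower number here means a stronger inhibitor of growth, a higher number a weaker inhibitor of growth), gives 11000 nM, the highest of the three numbers measured. Compound 2 `CC(C)(C)c1ccc(CNCCCNS(=O)(=O)c2cc(C(F)(F)F)cc(C(F)(F)F)c2)cc1` gives 2300 nM, and compound 3 `O=S(=O)(NCCNCc1ccc(-c2ccccc2)cc1)c1cc(C(F)(F)F)cc(C(F)(F)F)c1` gives 2700 nM. Going by the values given here, the one step that changes a single place, a 4.8-fold lower number from compound 1 to compound 2 (0.68 log units; beyond the scatter), shows that swapping the benzyl substituent from compound 1 can lower the number modestly. Compound 4 `O=S(=O)(NCCCCNCc1ccc(Br)cc1)c1cc(C(F)(F)F)cc(C(F)(F)F)c1` differs from compound 1 by ((4-bromobenzyl)amino)methyl in place of (2-chlorobenzyl)amino on a saturated chain carbon, three bonds along the chain from a sulfonamide nitrogen; the chain is one carbon longer and the halogen moves to a different ring position, so the earlier step bears only loosely on it. A lowering of similar or smaller size is expected, giving compound 4 an estimated 4500 nM, within 1500 nM to 14000 nM, a change of a 2.4-fold lower number from compound 1 to compound 4 (0.39 log units; beyond the scatter).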

Compound 4, concentration for 50% growth inhibition: 2100 nM
For compound 4 the middle estimate is 2.1-fold (0.33 log units) above the measured one, within the range that was stated.
By their numbers in this assay, from the lowest: compounds 4, 2 and 3 (each within the scatter of the next); then compound 1.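

In this assay, putting ((4-bromobenzyl)amino)methyl in place of (2-chlorobenzyl)amino gives a 5.2-fold lower number from compound 1 to compound 4 (0.72 log units; beyond the scatter) on the shared core. A modest lowering from compound 1 is therefore not confined to the 4-(tert-butyl)phenyl change, but this single step alters both the chain and the ring, so it cannot separate the two. No measured evidence here explains the lowering. Still open, as far as these compounds go, is which of the two alterations carries it. Also open, from the compounds shown here alone, is whether a ring bearing a nitrile or a carboxylic acid would give a similar number.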